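The source may hold more compounds than are shown below. What is called first, only, known or untested is meant among the compounds shown, and "the series" means these compounds.

Compound 3 `Cc1c(C(=O)N/N=C\c2c(O)cccc2Cl)oc2cccc(O)c12` belongs to a small set of compounds sharing one core. In a functional assay on PC-3 cells (Homo sapiens) for inhibition (a lower number here means a stronger inhibitor, a higher number a weaker inhibitor), compound 3 gives 18700 nM. Compound 1 `Cc1c(C(=O)N/N=C\c2cc(F)ccc2O)oc2cccc(O)c12` gives 3170 nM in this assay. For compound 2 `Cc1c(C(=O)N/N=C\c2ccncc2)oc2cccc(O)c12` this assay reports only a limit, >= 40000 nM. Among the numbers shown, compound 3 stands highest, its nearest neighbour being compound 1, with a 5.9-fold higher number from compound 1 to compound 3 (0.77 log units; beyond the scatter). The step of an at least 2.1-fold lower number from compound 2 to compound 3 (0.33 log units; beyond the scatter) shows a carbon-only ring bearing a hydroxyl giving a lower number than pyridin-4-yl. Compound 4 `Cc1c(C(=O)N/N=C\c2cccc(Br)c2O)oc2cccc(O)c12` has not yet been measured in this assay. It differs from compound 3 in one place: 3-bromo-2-hydroxyphenyl in place of 2-chloro-6-hydroxyphenyl on a carbon with a double bond to nitrogen. The change keeps a hydroxyl on a carbon-only ring, as in compound 1 and compound 3, and exchanges chlorine for bromine. Within the data shown here, the only measured step between two such rings, from compound 1 to compound 3, was modest, so a modest move toward a lower number is expected here: for compound 4 the expected step is a 3.1-fold lower number from compound 3 to compound 4 (0.49 log units; beyond the scatter). Compound 4 is estimated at 6000 nM, most likely between 1500 nM and 25000 nM.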

Compound 4, half-maximal inhibitory concentration: 16600 nM
Compound 4: the middle estimate sits 2.8-fold (0.44 log units) below what was measured; measured number inside the range.
By their numbers in this assay, from the lowest: compound 1; then compounds 4 and 3 (each within the scatter of the next). At a limit, above all of these: compound 2.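

In this assay the exchange of 2-chloro-6-hydroxyphenyl for 3-bromo-2-hydroxyphenyl gives a 1.1-fold lower number from compound 3 to compound 4 (0.05 log units; within the scatter) and so does not separate these two rings, even though both the halogen and the numbering of the ring positions change. The 5-fluoro-2-hydroxyphenyl ring still stands apart, with a 5.2-fold higher number from compound 1 to compound 4 (0.72 log units; beyond the scatter) showing that a hydroxyl on a carbon-only ring does not by itself fix the number. The step of an at least 2.4-fold lower number from compound 2 to compound 4 (0.38 log units; beyond the scatter) rests on a limit rather than a number, and it still puts the bromo ring on the lower side of pyridin-4-yl: the limit of >= 40000 nM in this assay, at which 1 of the 4 values shown sits.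

The compounds shown leave open whether the lower number of compound 1 follows from the fluorine itself or from the arrangement of groups on its ring. They also leave open how this ring would behave with an amine or a carboxylic acid in place of the halogen.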